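Swapping chloro for fluoro in a cytotoxicity series

This account rests on a few compounds, and the source may have more. Where it says the series, first, only, none or still open, it means among the compounds named here.

Compound 3 `COc1cc2[nH]c(C)c(-c3ccc(Oc4ccc(OC(F)(F)F)cc4)cc3)c(=O)c2cc1Cl` was tested in an ADME assay on HepG2 cells (Homo sapiens) for cytotoxicity, read by resazurin assay, with a stated time of 24 h; on this read-out higher numbers stand for weaker inhibition and lower numbers for stronger inhibition. In this assay compound 3 gives a limit of the assay, > 10000 nM. Compound 1 `COc1cc2[nH]c(C)c(-c3ccc(Oc4cccc(OC(F)(F)F)c4)cc3)c(=O)c2cc1Cl` also gives a limit, > 10000 nM. Compound 2 `COc1ccc2c(=O)c(-c3ccc(Oc4ccc(OC(F)(F)F)cc4)cc3)c(C)[nH]c2c1` gives a limit as well, > 10000 nM. Both recorded steps, a step that the two limits leave unreadable from compound 1 to compound 3 and a step that the two limits leave unreadable from compound 2 to compound 3, therefore cannot be sized, since (the limit of > 10000 nM in this assay, at which 3 of the 3 values shown sit). Compound 4 `COc1cc2[nH]c(C)c(-c3ccc(Oc4ccc(OC(F)(F)F)cc4)cc3)c(=O)c2cc1F` has not yet been measured; it differs from compound 3 by fluoro in place of chloro on an aromatic carbon. Among the measured compounds shown here, nothing among the measured steps bears readably on this change, so no step beyond the scatter is expected, and the step that the limit leaves unreadable from compound 3 to compound 4 is an estimate only. Compound 4 is therefore expected to give 15000 nM, within 8000 nM to 50000 nM, most likely again as a limit.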

Compound 4, half-maximal inhibitory concentration: > 10000 nM
Compound 4: only a limit was reported (the forecaster's own chance of this, stated with the estimate: 85%); the middle value lies beyond the limit too.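

No step from compound 3 or compound 2 to compound 4 can be read, because the values offer no measured number to compare: the limit of > 10000 nM in this assay, at which 4 of the 4 values shown sit.

As far as these compounds go, how chloro, fluoro and hydrogen on this aromatic carbon compare for cytotoxicity stays open.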